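Swapping the Chloropyrazole for a Dimethyltriazole

This account rests on a few compounds, and the source may have more. Where it says the series, first, only, none or still open, it means among the compounds named here.

Three compounds share one core and differ only in the ring sitting on the saturated chain carbon bound to the carbonyl carbon. In a functional assay on CHO-K1 cells for antagonist activity at C-X-C chemokine receptor type 3 (Homo sapiens), read by FLIPR, with a stated time of 10 min, in the presence of a further agent that is not named here (a higher number here means a weaker inhibitor, a lower number a stronger inhibitor), compound 1 `C[C@@H]1CN(c2sc(C(F)(F)F)nc2-c2nc3ccccc3[nH]2)CCN1C(=O)CN1C(=O)OC[C@@H]1c1ccccc1` gives 360 nM, compound 2 `C[C@@H]1CN(c2sc(C(F)(F)F)nc2-c2nc3ccccc3[nH]2)CCN1C(=O)Cn1cccn1` gives 13 nM, and compound 3 `C[C@@H]1CN(c2sc(C(F)(F)F)nc2-c2nc3ccccc3[nH]2)CCN1C(=O)Cn1cc(Cl)cn1` gives 1.7 nM, the lowest number of the three. The ring swaps moved the number strongly: a 28-fold lower number from compound 1 to compound 2 (1.44 log units; beyond the scatter) and a 210-fold lower number from compound 1 to compound 3 (2.33 log units; beyond the scatter), while the smaller change gave a 7.6-fold lower number from compound 2 to compound 3 (0.88 log units; beyond the scatter). Compound 4 `Cc1nc(C)n(CC(=O)N2CCN(c3sc(C(F)(F)F)nc3-c3nc4ccccc4[nH]3)C[C@H]2C)n1` carries 3,5-dimethyl-1H-1,2,4-triazol-1-yl in place of 4-chloro-1H-pyrazol-1-yl on a saturated chain carbon bound to a carbonyl carbon. The chloro that helped in the step from compound 2 to compound 3 is gone, and the two methyl groups and the extra ring nitrogen have no precedent among these compounds, so a modest rise is expected: a 5.9-fold higher number from compound 3 to compound 4 (0.77 log units; beyond the scatter). Compound 4 is therefore estimated at 10 nM, with a range of 3 nM to 40 nM.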

Compound 4, half-maximal inhibitory concentration: 3.2 nM
Estimate against measurement, compound 4: 3.1-fold (0.49 log units) above; low and high end bracket the measured number.
By their numbers in this assay, from the lowest: compounds 3 and 4 (each within the scatter of the next); then compound 2; then compound 1.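

At this position a low number does not depend on the chloro: a 1.9-fold higher number from compound 3 to compound 4 (0.27 log units; within the scatter) leaves the 3,5-dimethyl-1H-1,2,4-triazol-1-yl ring level with the 4-chloro-1H-pyrazol-1-yl ring. The triazole also improves on the unsubstituted pyrazole, with a 4.1-fold lower number from compound 2 to compound 4 (0.61 log units; beyond the scatter) showing that gain, while a 110-fold lower number from compound 1 to compound 4 (2.05 log units; beyond the scatter) marks a far larger one over the oxazolidinone ring. Nothing available explains these numbers. Still open, going by these compounds, is whether the two methyl groups or the extra ring nitrogen account for the result, which the unsubstituted 1H-1,2,4-triazol-1-yl ring could help separate.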